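The source may report more compounds than this note shows. Statements on the series, on what has been measured and on what is new or still open speak of the compounds shown alone.

In a functional assay on MCF7 cells (Homo sapiens) for inhibition, read by MTT assay, with a stated time of 48 h (a higher number here means a weaker inhibitor, a lower number a stronger inhibitor), compound 1 `COc1ccc(/C=C/c2cc(OC)cc(OC)c2/C=C/C(=O)NC2CC2)cc1` gives 3940 nM, the highest of the three numbers recorded, though compound 2 `CCC(C)NC(=O)/C=C/c1c(/C=C/c2ccc(OC)cc2)cc(OC)cc1OC` gives 3430 nM and compound 3 `COc1ccc(/C=C/c2cc(OC)cc(OC)c2/C=C/C(=O)NC(C)C)cc1` gives 2560 nM, both within the scatter of it. The steps among these three are all small: a 1.1-fold lower number from compound 1 to compound 2 (0.06 log units; within the scatter), a 1.5-fold lower number from compound 1 to compound 3 (0.19 log units; within the scatter) and a 1.3-fold lower number from compound 2 to compound 3 (0.13 log units; within the scatter). Compound 4 `COc1ccc(/C=C/c2cc(OC)cc(OC)c2/C=C/C(=O)N2CCC(c3ccccc3)CC2)cc1` differs from compound 1 by 4-phenylpiperidin-1-yl in place of cyclopropylamino on a carbonyl carbon. Going by the values given here, none of the measured steps removes the hydrogen-bond donor or brings in a six-membered aromatic ring, so they bear only loosely on this change; what they do show is that exchanging cyclopropyl, sec-butyl and isopropyl on the amide-type nitrogen left this assay unmoved beyond the scatter. With a change this much larger, the expected step is a 1.3-fold lower number from compound 1 to compound 4 (0.12 log units; within the scatter), treated as modest but with wide uncertainty in either direction. Compound 4 is therefore estimated at 3000 nM, with a range from 700 nM to 13000 nM.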

Compound 4, half-maximal inhibitory concentration: 4230 nM
Estimate against measurement, compound 4: 1.4-fold (0.15 log units) below, and the stated range covers the measured number.
By their numbers in this assay, from the lowest: compounds 3, 2, 1 and 4 (each within the scatter of the next).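

In this assay, 4-phenylpiperidin-1-yl on the carbonyl carbon stays within the scatter of all three smaller amino groups: a 1.1-fold higher number from compound 1 to compound 4 (0.03 log units; within the scatter), a 1.7-fold higher number from compound 3 to compound 4 (0.22 log units; within the scatter) and a 1.2-fold higher number from compound 2 to compound 4 (0.09 log units; within the scatter). The earlier compounds shown here only exchanged cyclopropyl, isopropyl and sec-butyl on a nitrogen that keeps its hydrogen, whereas compound 4 shows that this assay also stays within the scatter when the amide hydrogen is gone and a six-membered aromatic ring has entered. No measurement shown here accounts for this result.

Compound 4 brings these changes in together, and the compounds shown do not separate them; a plain piperidin-1-yl or a benzylamino group on the same carbonyl carbon would bear on that. From the compounds shown here alone, how an amine or a carboxylic acid on the phenyl ring of this group would read remains open.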